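Removing the para-methyl: compound 3 to compound 4

The source may report more compounds than this note shows. Statements on the series, on what has been measured and on what is new or still open speak of the compounds shown alone.

Compound 1 `CCN(CC)CCCOc1cc2ncnc(Nc3nc4ccc(C(=O)Nc5c(C)cccc5C)cc4s3)c2cc1OC`: > 100000 nM
Compound 2 `COc1cc2c(Nc3nc4ccc(C(=O)Nc5c(C)cccc5C)cc4s3)ncnc2cc1OCCCN1CCC(C)CC1`: > 100000 nM
Compound 3 `COc1cc2c(Nc3nc4ccc(C(=O)Nc5c(C)cc(C)cc5C)cc4s3)ncnc2cc1OCCCN1CCCC1`: 5900 nM

Of the compounds shown here, three sharing one core have been measured in a functional assay on DLD-1 cells (Homo sapiens) for cytotoxicity, read by WST assay, with a stated time of 72 h; on this read-out higher numbers stand for weaker inhibition and lower numbers for stronger inhibition. Compound 1 gives only a limit of the assay, > 100000 nM. Compound 2 likewise gives only a limit, > 100000 nM. Compound 3, with 5900 nM, is the one number shown; the two others sit at the limit of > 100000 nM in this assay, at which 2 of the 3 values shown sit, so the step that the two limits leave unreadable from compound 1 to compound 2 cannot be read.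

Compound 4 `COc1cc2c(Nc3nc4ccc(C(=O)Nc5c(C)cccc5C)cc4s3)ncnc2cc1OCCCN1CCCC1` differs from compound 3 by hydrogen in place of methyl on an aromatic carbon. For the measured compounds named here, no measured step removes this methyl, so nothing directly tells how large the change will be. Compounds 1 and 2, which carry the same (2,6-dimethylphenyl)carbamoyl as compound 4 but other amines, both sit at the limit, while compound 3 with the (2,4,6-trimethylphenyl)carbamoyl gives a number. Compound 4 is therefore expected to lose activity, with a step of a 6.8-fold higher number from compound 3 to compound 4 (0.83 log units; beyond the scatter) in this assay. The estimate for compound 4 is 40000 nM, within 8000 nM to 150000 nM, with a fair chance that only a limit is returned.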

Compound 4, half-maximal inhibitory concentration: > 100000 nM
Compound 4 ended at the assay's limit; the forecaster's own chance of this, stated with the estimate: 50%; at least 2.5-fold (0.39 log units) between middle value and limit.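

In this assay, the methyl on this aromatic carbon, para to a large group, proves to matter: removing it gives an at least 16-fold higher number from compound 3 to compound 4 (1.22 log units; beyond the scatter) with nothing else changed. This is the first readable step in the series, and with pyrrolidin-1-yl held constant it ties the one number shown to the (2,4,6-trimethylphenyl)carbamoyl, not to the amine alone. Compound 4 gives only a limit of the assay, and the steps from compound 1 and compound 2 to it cannot be read, so the three amines stay unranked: the limit of > 100000 nM in this assay, at which 3 of the 4 values shown sit.

Going by these compounds, whether this methyl is specifically required stays open; an ethyl, a methoxy or a chlorine on the same aromatic carbon would test that. Also open, on these data alone, is whether diethylamino or 4-methylpiperidin-1-yl gives a number when paired with the (2,4,6-trimethylphenyl)carbamoyl.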